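The source may report more compounds than this note shows. Statements on the series, on what has been measured and on what is new or still open speak of the compounds shown alone.

Measured in a toxicity assay on CCRF-CEM cells (Homo sapiens) for cytotoxicity; on this read-out higher numbers stand for lower toxicity in this test and lower numbers for higher toxicity in this test:
- compound 1 `Cc1cccc2c1nc(-c1c(F)cccc1F)n2Cc1c(F)cccc1F`: > 100 uM
- compound 2 `CC(=O)N(C)c1cccc2c1nc(-c1c(F)cccc1F)n2Cc1c(F)cccc1F`: > 100 uM

Not yet measured: compound 3 `CNc1cccc2c1nc(-c1c(F)cccc1F)n2Cc1c(F)cccc1F`.

In this assay compound 2 gives > 100 uM, which is a limit of the assay and not a number. Compound 1 also stands at a limit, > 100 uM. The whole measured record therefore reads: the limit of > 100 uM in this assay, at which 2 of the 2 values shown sit.

The next step is hydrogen in place of acetyl on a nitrogen on an aromatic ring, that is, acetyl(methyl)amino to methylamino: hydrogen in place of acetyl on a nitrogen on an aromatic ring.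

Within the data shown here, one measured step bears on this, a step that the two limits leave unreadable from compound 1 to compound 2. Among the measured compounds shown here, it involves the same acetyl(methyl)amino group, but it has no readable size, and no measured step shows the effect of losing the acetyl. For the measured compounds named here, the data therefore support no firm step in this assay, and no direction can be assigned. The working expectation is that toxicity stays low and the result again falls at or close to the limit. The expected change is a number no higher from compound 2 to compound 3 (the limit leaves the size open). For compound 3 the estimated value is 100 uM, with an expected range of 30 uM to 200 uM.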

Compound 3, half-maximal toxic concentration: 27.2 uM
Estimate against measurement, compound 3: 3.7-fold (0.57 log units) above, outside the stated range (below it).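

In this assay, among these compounds, hydrogen in place of acetyl on a nitrogen on an aromatic ring gives the first value that is a number and not a limit, with an at least 3.6-fold lower number from compound 2 to compound 3 (0.56 log units; beyond the scatter). Methylamino in place of methyl on an aromatic carbon gives an at least 3.6-fold lower number from compound 1 to compound 3 (0.56 log units; beyond the scatter), so this position is not indifferent to its group on this read-out, and of the three compounds, compound 3 shows the higher toxicity in this test. The step between compound 1 and compound 2 cannot be read, and the two steps to compound 3 give only minimum sizes because compound 1 and compound 2 both stand at a limit: the limit of > 100 uM in this assay, at which 2 of the 3 values shown sit.

Still open, going by these compounds, is whether the lower number goes with the methylamino group as a whole, which a primary amine, a dimethylamino group or a longer chain on the same nitrogen would help to separate. Also open, on these data alone, is whether an acetylamino group, with the acetyl kept and the methyl replaced by hydrogen, would stay at the limit in this assay.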